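Compound 3 and the loss of one fluoro

The source may hold more compounds than are shown below. What is called first, only, known or untested is meant among the compounds shown, and "the series" means these compounds.

Measured in an ADME assay on HEK293 cells (Homo sapiens) for cytotoxicity, read by resazurin assay, with a stated time of 48 h; a higher number here means that more compound is tolerated, a lower number that less compound is tolerated:
- Compound 1 `O=S(=O)(Nc1ccc(-c2nc3ccccc3o2)cc1)c1ccc(Cl)s1`: > 100000 nM, a limit of the assay
- Compound 2 `O=S(=O)(Nc1ccc(-c2nc3ccccc3o2)cc1)c1cccc(O)c1`: > 100000 nM, a limit of the assay
- Compound 3 `O=S(=O)(Nc1ccc(-c2nc3ccccc3o2)cc1)c1ccc(F)c(C(F)(F)F)c1`: 82000 nM

Within the data shown here, compound 3 holds the only true number in this small set, 82000 nM. Compound 1 and compound 2 give no number, and they stand at the limit of > 100000 nM in this assay, at which 2 of the 3 values shown sit. The next compound to be tested is compound 4 `O=S(=O)(Nc1ccc(-c2nc3ccccc3o2)cc1)c1cccc(C(F)(F)F)c1`, which has hydrogen in place of fluoro on an aromatic carbon, ortho to a trifluoromethyl group and para to a large group: hydrogen in place of fluoro on an aromatic carbon.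

Little in the measurements bears on this change. Among the measured compounds shown here, the one measured step, a step that the two limits leave unreadable from compound 1 to compound 2, swaps the whole group on the sulfonyl sulfur and offers no size to carry over. The firmest guide is the reading of compound 3, 82000 nM. That reading lies close to the limit of > 100000 nM in this assay, at which 2 of the 3 values shown sit. A change of a single fluoro is therefore expected to shift the reading by no more than the scatter, with a slight lean towards more compound being tolerated. The expected step is a 1.1-fold higher number from compound 3 to compound 4 (0.04 log units; within the scatter). Compound 4 may well return only a limit. For a numerical reading, compound 4 is estimated at 90000 nM, with an expected range from 45000 nM to 160000 nM.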

Compound 4, half-maximal cytotoxic concentration: > 100000 nM
Compound 4: a limit, no number; the forecaster's own chance of this, stated with the estimate: 45%; at least 1.1-fold (0.04 log units) between middle value and limit.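

With the trifluoromethyl group kept, hydrogen in place of fluoro on this aromatic carbon, ortho to a trifluoromethyl group and para to a large group, gives in this assay an at least 1.2-fold higher number from compound 3 to compound 4 (0.08 log units; that floor lies within the scatter). The step is only a floor, and it lies within the scatter, so the result does not show that the fluoro matters to the reading; it shows only that its loss brought no lower number at this position. Compound 4 returns no number, only a limit of the assay, so compound 3 remains the sole compound with a true reading, and the set now sits mostly at one ceiling: the limit of > 100000 nM in this assay, at which 3 of the 4 values shown sit.

The steps that join two limits, such as trifluoromethyl in place of hydroxy, cannot be read, so the groups at those compounds cannot be ranked against one another. Going by these compounds, what stays open is whether an amine or a carboxylic acid on this aromatic carbon would bring the reading down to a true number, and what happens when the trifluoromethyl group gives way to a methyl group while the fluoro stays.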